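Three Aryl Groups, One Position, Flat Numbers

A few compounds are considered here, and "the series" means these few. Any claim that something is new, unique, unknown or untested is made for them only; others in the source may bear on it.

Compound 1, `Cc1nc2c3ccccc3ccc2c2nc3c(ccc4ccccc43)c(-c3cccnc3)c12`: 98.2 ug/mL
Compound 2, `Cc1nc2c3ccccc3ccc2c2nc3c(ccc4ccccc43)c(-c3cc([N+](=O)[O-])ccc3N)c12`: 93.1 ug/mL
Compound 3, `Cc1nc2c3ccccc3ccc2c2nc3c(ccc4ccccc43)c(-c3ccccc3N)c12`: 95.4 ug/mL

In a functional assay, read by spectrophotometry, with a stated time of 30 min (a higher number here means a weaker inhibitor, a lower number a stronger inhibitor), compound 2 gives the lowest of the three numbers, but the steps linking it to the others, a 1.1-fold lower number from compound 1 to compound 2 (0.02 log units; within the scatter) and a 1.0-fold higher number from compound 2 to compound 3 (0.01 log units; within the scatter), both fall within the scatter, so no order among the three can be read.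

Compound 4, `Cc1nc2c3ccccc3ccc2c2nc3c(ccc4ccccc43)c(-c3cc(O)nc4ccccc34)c12`, carries 2-hydroxyquinolin-4-yl in place of 2-amino-5-nitrophenyl on an aromatic carbon. For the measured compounds named here, the steps that bear on this change are those that swapped the group on the same aromatic carbon, a 1.1-fold lower number from compound 1 to compound 2 (0.02 log units; within the scatter) and a 1.0-fold lower number from compound 1 to compound 3 (0.01 log units; within the scatter), together with a 1.0-fold higher number from compound 2 to compound 3 (0.01 log units; within the scatter); each stayed within the scatter, so three different groups at this position left the number essentially unchanged. One therefore expects no step beyond the scatter, a 1.0-fold higher number from compound 2 to compound 4 (0.01 log units; within the scatter). Compound 4 is estimated at 95 ug/mL, with a range from 60 ug/mL to 150 ug/mL.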

Compound 4, half-maximal inhibitory concentration: 92.1 ug/mL
Beside the measured number, compound 4's estimate is 1.0-fold (0.01 log units) above it; measured number inside the range.
By their numbers in this assay, from the lowest: compounds 4, 2, 3 and 1 (each within the scatter of the next).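

In this assay a group of two fused six-membered aromatic rings on this aromatic carbon, opposite the ring nitrogen, reads like the single-ring groups: the record gives a 1.0-fold lower number from compound 2 to compound 4 (0.00 log units; within the scatter) and a 1.0-fold lower number from compound 3 to compound 4 (0.02 log units; within the scatter) and also a 1.1-fold lower number from compound 1 to compound 4 (0.03 log units; within the scatter) with every step inside the scatter. The flat picture at this position therefore now covers 2-hydroxyquinolin-4-yl as well, across all four compounds. No evidence on hand accounts for this flatness. On these data alone, whether a simple amine, a carboxylic acid or a longer alkyl chain on this carbon would shift the number stays open. So does the role of the methyl on the shared core.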